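Three Tolerated Anilinopyrimidines and a Larger Cyclohexenylethyl Variant

A few compounds are considered here, and "the series" means these few. Any claim that something is new, unique, unknown or untested is made for them only; others in the source may bear on it.

Compound 1, `COc1cc2cc(C#N)ccc2c(OC)c1Oc1cc(NC(C)C)nc(Nc2ccc(C#N)cc2)n1`, in an ADME assay on MT4 cells (Homo sapiens) for cytotoxicity, read by MTT assay, with a stated time of 5 days (a lower number here means that less compound is tolerated, a higher number that more compound is tolerated), gives only a limit, > 125000 nM.
Compound 2, `COc1cc2cc(C#N)ccc2c(OC)c1Oc1cc(NC(C)(C)C)nc(Nc2ccc(C#N)cc2)n1`, in this assay gives only a limit, > 125000 nM.
Compound 3, `CCC(C)Nc1cc(Oc2c(OC)cc3cc(C#N)ccc3c2OC)nc(Nc2ccc(C#N)cc2)n1`, in this assay gives only a limit, > 125000 nM.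

All three measured compounds sit at the limit of > 125000 nM in this assay, at which 3 of the 3 values shown sit, so none of the steps between them can be read: a step that the two limits leave unreadable from compound 1 to compound 2, a step that the two limits leave unreadable from compound 1 to compound 3 and a step that the two limits leave unreadable from compound 2 to compound 3 are all left open by the two limits. Compound 3 therefore stands only as a limit, and the other two values shown are limits as well.

Compound 4, `COc1cc2cc(C#N)ccc2c(OC)c1Oc1cc(NCCC2=CCCCC2)nc(Nc2ccc(C#N)cc2)n1`, differs from compound 3 in one place: 2-(cyclohex-1-en-1-yl)ethyl in place of sec-butyl on a nitrogen on an aromatic ring. For the measured compounds named here, no measured step bears on this change, since the three available steps are unreadable; the only thing known is that compound 3 and both of its neighbours were tolerated up to the assay limit. On that basis compound 4 is expected to show no step beyond the scatter, a number no higher from compound 3 to compound 4 (the limit leaves the size open). Compound 4 is estimated at 125000 nM, with a range from 50000 nM to 300000 nM, most likely again reported as a limit.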

Compound 4, half-maximal cytotoxic concentration: > 125000 nM
Compound 4 ended at the assay's limit (the forecaster's own chance of this, stated with the estimate: 65%); the middle value sits exactly at the limit.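

No step from compound 1, compound 2 or compound 3 to compound 4 can be read, since each value is only a limit: the limit of > 125000 nM in this assay, at which 4 of the 4 values shown sit.

The compounds shown leave open how much of any of them is tolerated in this assay, and whether 2-(cyclohex-1-en-1-yl)ethyl differs there from the smaller groups.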